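Phenylethenyl in place of chlorophenyl: outlook for compound 3

A few compounds are considered here, and "the series" means these few. Any claim that something is new, unique, unknown or untested is made for them only; others in the source may bear on it.

Compound 2 `Cc1cc(O)c(C2=NN(c3ccc(S(N)(=O)=O)cc3)C(c3ccccc3Cl)C2)cc1Cl` gives only a limit in a functional assay on NCI-H226 cells (Homo sapiens) for antiproliferative activity, with a stated time of 48 h (on this read-out lower numbers stand for higher toxicity in this test and higher numbers for lower toxicity in this test), namely > 100000 nM, which is the assay limit noted as the limit of > 100000 nM in this assay, at which 1 of the 2 values shown sits. Its analogue compound 1 `Cc1cc(O)c(C2=NN(c3ccc(S(N)(=O)=O)cc3)C(c3ccccc3O)C2)cc1Cl` gives 86500 nM in this assay, and an at least 1.1-fold higher number from compound 1 to compound 2 (0.06 log units; that floor lies within the scatter) stays within the scatter. Compound 3 `Cc1cc(O)c(C2=NN(c3ccc(S(N)(=O)=O)cc3)C(/C=C/c3ccccc3)C2)cc1Cl` differs from compound 2 by 2-phenylethenyl in place of 2-chlorophenyl on a saturated ring carbon. Going by the values given here, no measured step touches this saturated ring carbon; the single known step concerns the hydroxy-to-chloro change on the aromatic carbon and lies within the scatter. With compound 2 at the limit, the step of an at least 1.1-fold lower number from compound 2 to compound 3 (0.04 log units; that floor lies within the scatter) is expected to remain within the scatter. Compound 3 is therefore expected to give 90000 nM in this assay, between 35000 nM and 250000 nM.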

Compound 3, concentration lethal to 50% of the cells: 51800 nM
Estimate against measurement, compound 3: 1.7-fold (0.24 log units) above; the measured number falls inside the stated range.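

This saturated ring carbon now shows a change of the whole group, not only of its hydroxy or chloro substituent. In this assay, 2-phenylethenyl with its double bond outside aromatic rings stays level with 2-hydroxyphenyl: a 1.7-fold lower number from compound 1 to compound 3 (0.22 log units; within the scatter). Compound 2 gives a limit, not a number: the limit of > 100000 nM in this assay, at which 1 of the 3 values shown sits. Read against that limit, the step is only a floor: an at least 1.9-fold lower number from compound 2 to compound 3 (0.28 log units; that floor lies within the scatter).

As far as these compounds go, whether an amine or a carboxylic acid on this carbon would take the number beyond the scatter stays open. The same holds for a longer chain in place of 2-phenylethenyl.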